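Rat clearance notes on the benzoxazolone hydroxy-cyclohexyl series

A few compounds are considered here, and "the series" means these few. Any claim that something is new, unique, unknown or untested is made for them only; others in the source may bear on it.

Compound 3 `O=C(C[C@]1(O)CC[C@@H](Cc2ccc(C(F)(F)F)cc2)CC1)Nc1ccc2[nH]c(=O)oc2c1` has no clearance number in an ADME assay on the whole organism (strain Sprague-Dawley) for pharmacokinetics, with Rattus norvegicus as the target, using cassette dosing (on this read-out lower numbers stand for slow clearance and higher numbers for fast clearance), its entry reading "not determined" (no result reported); the same holds for compound 1 `O=C(C[C@]1(O)CC[C@@H](Cc2ccc(Cl)cc2)CC1)Nc1ccc2[nH]c(=O)oc2c1`, whose entry reads "not determined" (no result reported), so the series carries a single measured point. In this assay compound 2 `COc1ccc(C[C@H]2CC[C@](O)(CC(=O)Nc3ccc4[nH]c(=O)oc4c3)CC2)cc1` gives 45.9 mL/min/kg, which is the only anchor for the expectations below.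

Compound 4 `O=C(C[C@]1(O)CC[C@@H](Cc2ccc(F)c(F)c2)CC1)Nc1ccc2[nH]c(=O)oc2c1` differs from compound 3 in one place: 3,4-difluorophenyl in place of 4-(trifluoromethyl)phenyl on a saturated chain carbon bound to a saturated ring carbon. With compound 3 itself unmeasured, no step size can be read from data; the expected difference from compound 3 to compound 4 in this assay is none beyond the usual scatter, in no preferred direction.

Resting on compound 2 alone, compound 4 is expected to give about 35 mL/min/kg in this assay, with a range from 15 mL/min/kg to 70 mL/min/kg.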

Compound 4, clearance: 35.7 mL/min/kg
Beside the measured number, compound 4's estimate is 1.0-fold (0.01 log units) below it, within the range that was stated.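

At this place, on a saturated chain carbon bound to a saturated ring carbon, 3,4-difluorophenyl in place of 4-methoxyphenyl gives a 1.3-fold lower number from compound 2 to compound 4 (0.11 log units; within the scatter) in this assay, so this exchange leaves the read-out unresolved from the scatter. Steps involving compound 1 or compound 3 cannot be read, and the place has this single comparison. Nothing at hand explains the result.

Still open, as far as these compounds go, is whether a carboxylic acid or an amine on the phenyl ring at this place would move clearance beyond the scatter.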